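Adding a Methoxy Group to a Chalcone-Type Pyrazole

A few compounds are considered here, and "the series" means these few. Any claim that something is new, unique, unknown or untested is made for them only; others in the source may bear on it.

Measured compounds:
compound 1 `COc1ccc(C(=O)/C=C/c2cc(-c3cc(OC)c(OC)c(OC)c3)n[nH]2)cc1OC` gives 97%
compound 2 `COc1cc(-c2cc(/C=C/C(=O)c3ccc(F)c(F)c3)[nH]n2)cc(OC)c1OC` gives 95%

In a functional assay on CAKI-1 cells (Homo sapiens) for cytotoxicity, read by sulforhodamine B assay, with a stated time of 48 h, tested at 0.01 uM (a lower number here means a stronger effect, a higher number a weaker effect of the compound at the concentration tested), compound 1 gives 97%, and in this assay compound 2 gives 95%. The two numbers lie within the scatter of each other, as the step of a number 2 percentage points lower from compound 1 to compound 2 (within the scatter) shows, so neither compound can be set apart from the other on this readout; both leave most of the cells' response in place at the concentration tested.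

Compound 3 `COc1cc(C(=O)/C=C/c2cc(-c3cc(OC)c(OC)c(OC)c3)n[nH]2)cc(OC)c1OC` has not yet been measured in this assay. It differs from compound 1 by methoxy in place of hydrogen on an aromatic carbon. Within the data shown here, no measured step touches this change; the only step known, a number 2 percentage points lower from compound 1 to compound 2 (within the scatter), exchanges the whole ring on the carbonyl carbon and stays within the scatter. On that basis no step beyond the scatter is expected, and compound 3 is estimated at 95% within 82% to 104%, an expected step of a number 2 percentage points lower from compound 1 to compound 3 (within the scatter).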

Compound 3, a percentage reported as activity, at one concentration (the size of the read-out at that concentration, not a potency): 91%
Beside the measured number, compound 3's estimate is 4 percentage points above it; the measured number falls inside the stated range.
By their numbers in this assay, from the lowest: compounds 3, 2 and 1 (each within the scatter of the next).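

In this assay, among these compounds, methoxy in place of hydrogen on an aromatic carbon, ortho to a methoxy group and meta to a large group, gives a number 6 percentage points lower from compound 1 to compound 3 (within the scatter), the first reading at this position. The core of compound 1 therefore takes this added methoxy group without a change that can be told from the scatter at the concentration tested. Nothing measured on these compounds speaks to the reason for this result.

The compounds shown leave open whether another group on this aromatic carbon, such as an amine, a carboxylic acid or a longer alkoxy chain, would move the number beyond the scatter. They also leave open how all three compounds behave at concentrations other than the one tested.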